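Nitrocatechol chalcones: cyano for hydroxy on the aryl ring

The source may report more compounds than this note shows. Statements on the series, on what has been measured and on what is new or still open speak of the compounds shown alone.

Compound 1 `O=C(/C=C/c1ccoc1)c1cc(O)c(O)c([N+](=O)[O-])c1` and compound 2 `O=C(/C=C/c1cccc(O)c1)c1cc(O)c(O)c([N+](=O)[O-])c1` share one core and differ only on the aryl end of the chain. In an assay on isolated protein for inhibition of Amine oxidase [flavin-containing] A (Homo sapiens), read by fluorescence (on this read-out lower numbers stand for stronger inhibition and higher numbers for weaker inhibition), compound 1 gives 52900 nM, and compound 2 gives 43900 nM. The step of a 1.2-fold lower number from compound 1 to compound 2 (0.08 log units; within the scatter) is the only one measured in the series, and it stays within the scatter. Compound 2 thus has the lowest of the two numbers, with compound 1 only a small distance away.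

Compound 3 `N#Cc1cccc(/C=C/C(=O)c2cc(O)c(O)c([N+](=O)[O-])c2)c1` carries the change (cyano in place of hydroxy on an aromatic carbon). Among the compounds with values here, no measured step bears directly on a cyano for hydroxy exchange; the one step at hand changed the same aryl region without effect beyond the scatter. A step of size a 1.0-fold higher number from compound 2 to compound 3 (0.01 log units; within the scatter) is therefore expected, in no clear direction. Compound 3 is estimated at 45000 nM in this assay, with a range from 15000 nM to 130000 nM.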

Compound 3, half-maximal inhibitory concentration: 58900 nM
Estimate against measurement, compound 3: 1.3-fold (0.12 log units) below; the range from low to high includes it.
By their numbers in this assay, from the lowest: compounds 2, 1 and 3 (each within the scatter of the next).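

In this assay the exchange of hydroxy for cyano on an aromatic carbon, meta to a large group, gives a small step (a 1.3-fold higher number from compound 2 to compound 3 (0.13 log units; within the scatter)) and does not separate the two groups. This pair removes the hydrogen-bond donor of the hydroxy group while the number stays within the scatter, so on this read-out a donor at this position is not required to stay level with compound 2. No measurement given here explains this result.

From the compounds shown here alone, whether an amine or a carboxylic acid on the same aromatic carbon would give a step beyond the scatter remains open. Also open, going by these compounds, is whether cyano and hydroxy would still read alike at another place on the ring, or with the nitro group of the shared core replaced by a methoxy group.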